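The source may hold more compounds than are shown below. What is called first, only, known or untested is meant among the compounds shown, and "the series" means these compounds.

Compound 1 `CC1CC/C(=N\Nc2ccc(Br)cc2)c2ncc(C(=O)O)c(=O)n21` and compound 2 `COc1ccc(N/N=C2\CCC(C)n3c2ncc(C(=O)O)c3=O)cc1` share one core and differ only in the group on the aromatic ring. In a functional assay on the whole organism for inhibition, with Rattus norvegicus as the target (on this read-out higher numbers stand for an effect only at larger amounts of compound and lower numbers for an effect already at smaller amounts), compound 1 gives 0.8 umol/kg, and in this assay compound 2 gives 0.8 umol/kg, so compound 2 stands level with compound 1, the step of no change at the digits printed from compound 1 to compound 2 (within the scatter) lying within the scatter. Compound 3 `CCOc1ccc(N/N=C2\CCC(C)n3c2ncc(C(=O)O)c3=O)cc1` is derived from compound 2 by the change (methyl in place of hydrogen on a saturated chain carbon bound to an oxygen on an aromatic ring).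

Among the measured compounds shown here, the only measured step that bears on this one is the exchange of the aromatic substituent from compound 1 to compound 2, which left the dose unchanged; there is no measured step that lengthens the alkoxy chain itself. Compound 3 is therefore expected to show no step beyond the scatter in this assay, that is a step of about a 1.3-fold higher number from compound 2 to compound 3 (0.10 log units; within the scatter). Compound 3 is estimated at 1 umol/kg, with a range from 0.4 umol/kg to 2.5 umol/kg.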

Compound 3, dose for 50% inhibition: 1.6 umol/kg
Compound 3: middle estimate off by 1.6-fold (0.20 log units), on the low side; the measured number falls inside the stated range.
By their numbers in this assay, from the lowest: compounds 1, 2 and 3 (each within the scatter of the next).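

Read directly on the alkoxy group for the first time, methyl in place of hydrogen on the saturated chain carbon bound to the oxygen, that is methoxy to ethoxy, gives a 2.0-fold higher number from compound 2 to compound 3 (0.30 log units; within the scatter) in this assay and so does not move the dose beyond the scatter. Ethoxy in place of bromo on the aromatic carbon gives a 2.0-fold higher number from compound 1 to compound 3 (0.30 log units; within the scatter) as its reading, so bromo, methoxy and ethoxy at this place cannot be told apart in this assay on these numbers. Nothing at hand bears on the reason for this reading and no cause can be assigned to it.

The compounds shown leave open whether a longer chain, such as propoxy or butoxy, would stay within the scatter as well. They also leave open what an amine or a carboxylic acid on the same aromatic carbon would do to the dose.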